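The source may report more compounds than this note shows. Statements on the series, on what has been measured and on what is new or still open speak of the compounds shown alone.

Measured compounds:
compound 1 `CCOc1c(-c2cc(OC)c(OC)c(OC)c2)oc2ccccc2c1=O` — 5400 nM
compound 2 `CCCCOc1c(-c2cc(OC)c(OC)c(OC)c2)oc2ccccc2c1=O` — 8900 nM
compound 3 `CCN(CC)CCCOc1c(-c2cc(OC)c(OC)c(OC)c2)oc2ccccc2c1=O` — 37600 nM

In a functional assay on LNCaP cells (Homo sapiens) for antiproliferative activity, read by WST assay, with a stated time of 3 days (on this read-out higher numbers stand for weaker inhibition and lower numbers for stronger inhibition), compound 2 holds the second highest of the three numbers; its nearest neighbour is compound 1, a step within the scatter (a 1.6-fold higher number from compound 1 to compound 2 (0.22 log units; within the scatter)), and its furthest is compound 3 (a 4.2-fold higher number from compound 2 to compound 3 (0.63 log units; beyond the scatter)). Compound 4 `CCCN(CCC)CCCOc1c(-c2cc(OC)c(OC)c(OC)c2)oc2ccccc2c1=O` differs from compound 2 in one place: dipropylamino in place of methyl on a saturated chain carbon, three bonds along the chain from an oxygen on an aromatic ring. The measured step that bears on this most directly is a 4.2-fold higher number from compound 2 to compound 3 (0.63 log units; beyond the scatter), where a diethylamino group entered at the same place, a modest rise beyond the scatter; a 7.0-fold higher number from compound 1 to compound 3 (0.84 log units; beyond the scatter) points the same way. A comparable or slightly larger rise is therefore expected for the dipropylamino analogue, a 5.1-fold higher number from compound 2 to compound 4 (0.70 log units; beyond the scatter). Compound 4 is accordingly estimated at 45000 nM, with a range of 15000 nM to 130000 nM.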

Compound 4, half-maximal inhibitory concentration: 17900 nM
Estimate against measurement, compound 4: 2.5-fold (0.40 log units) above; the measured number falls inside the stated range.
By their numbers in this assay, from the lowest: compounds 1, 2 and 4 (each within the scatter of the next, the first and the last beyond it); then compound 3.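

In this assay, the amine at this place does not settle the number by itself: dipropylamino in place of diethylamino changes it (a 2.1-fold lower number from compound 3 to compound 4 (0.32 log units; beyond the scatter)), which shows that the groups on the nitrogen count. The dipropylamino compound stays within the scatter of the butyl compound (a 2.0-fold higher number from compound 2 to compound 4 (0.30 log units; within the scatter)), but not of the ethyl compound (a 3.3-fold higher number from compound 1 to compound 4 (0.52 log units; beyond the scatter)). Nothing measured here explains this difference. Open, as far as these compounds go, is how a dimethylamino or dibutylamino group would compare at this place, which would show whether larger groups on the nitrogen continue this trend. From the compounds shown here alone, a morpholine ring or a longer chain carrying the amine also remains open.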